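From a Halogenated Benzyl to a Methoxyphenyl Group

The compounds below may be only part of what the source reports. "The series", "measured", "known", "first", "only" and "open" are said of these compounds alone.

Compound 3 `O=S(=O)(NCCCNCc1ccc(Cl)c(C(F)(F)F)c1)c1cc(C(F)(F)F)cc(C(F)(F)F)c1` gives 5900 nM in a functional assay on A2780 cells (Homo sapiens) for inhibition, read by MTT assay, with a stated time of 72 h (on this read-out higher numbers stand for weaker inhibition of growth and lower numbers for stronger inhibition of growth), the highest of the three numbers measured. Compound 1 `O=S(=O)(NCCNCc1ccc(-c2ccccc2)cc1)c1cc(C(F)(F)F)cc(C(F)(F)F)c1` gives 2600 nM in this assay, and compound 2 `O=S(=O)(NCCCNCc1ccc(Cl)c(Cl)c1)c1cc(C(F)(F)F)cc(C(F)(F)F)c1` gives 1500 nM. For the measured compounds named here, the one measured step touching the group on a saturated chain carbon bound to an amine nitrogen is a 3.9-fold higher number from compound 2 to compound 3 (0.59 log units; beyond the scatter). Compound 4 `COc1ccc(CNCCCNS(=O)(=O)c2cc(C(F)(F)F)cc(C(F)(F)F)c2)cc1` carries 4-methoxyphenyl in place of 4-chloro-3-(trifluoromethyl)phenyl on a saturated chain carbon bound to an amine nitrogen. Going by the values given here, no measured step exchanges that whole group, so the modest step between compound 2 and compound 3 is the only guide, and a change of similar or smaller size is expected, with no firm direction. Compound 4 is therefore expected to give about 7000 nM, within 2500 nM to 20000 nM. That estimate means an expected 1.2-fold higher number from compound 3 to compound 4 (0.07 log units; within the scatter).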

Compound 4, concentration for 50% growth inhibition: 1700 nM
The estimate for compound 4 lay 4.1-fold (0.61 log units) above the measured number; the measured number lies below the stated range.
By their numbers in this assay, from the lowest: compounds 2, 4 and 1 (each within the scatter of the next); then compound 3.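

On a saturated chain carbon bound to an amine nitrogen, 4-methoxyphenyl in place of 4-chloro-3-(trifluoromethyl)phenyl gives a 3.5-fold lower number from compound 3 to compound 4 (0.54 log units; beyond the scatter) and shows that a group without any halogen can reverse the rise seen with trifluoromethyl. Set against 3,4-dichlorophenyl, the same group gives a 1.1-fold higher number from compound 2 to compound 4 (0.05 log units; within the scatter) and so cannot be told apart from it here. No measured evidence accounts for either step. The compounds shown leave open whether the oxygen of the methoxy group matters at this place. A plain phenyl, 4-methylphenyl or 4-hydroxyphenyl group would bear on that question.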